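The compounds below may be only part of what the source reports. "The series", "measured", "known", "first", "only" and "open" are said of these compounds alone.

Going by the values given here, compound 2 `CC(C(=O)NCc1ccc(C(F)(F)F)nc1N1CCN(c2ccc(C(F)(F)F)cc2)CC1)c1ccc(NS(C)(=O)=O)c(F)c1` gives the highest of the two numbers so far in a functional assay on CHO-K1 cells for antagonist activity at transient receptor potential cation channel subfamily V member 1 (Homo sapiens), read by FLIPR (on this read-out higher numbers stand for weaker inhibition and lower numbers for stronger inhibition), namely 117 nM, while compound 1 `Cc1cccc(N2CCN(c3nc(C(F)(F)F)ccc3CNC(=O)C(C)c3ccc(NS(C)(=O)=O)c(F)c3)CC2)c1` gives 39.2 nM. Among the compounds with values here, the one measured step, a 3.0-fold higher number from compound 1 to compound 2 (0.47 log units; beyond the scatter), concerns the same ring but a different group, so it bears only loosely on the change to compound 3 `COc1ccc(N2CCN(c3nc(C(F)(F)F)ccc3CNC(=O)C(C)c3ccc(NS(C)(=O)=O)c(F)c3)CC2)cc1`, where (methoxy in place of trifluoromethyl on an aromatic carbon). Within the data shown here, no step speaks to this change directly; the expectation is therefore a modest move, if any, towards the lower numbers seen in the set, roughly a 1.8-fold lower number from compound 2 to compound 3 (0.26 log units; within the scatter). Compound 3 is accordingly estimated at 65 nM, within 20 nM to 200 nM.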

Compound 3, half-maximal inhibitory concentration: 44.5 nM
Compound 3: the middle estimate sits 1.5-fold (0.16 log units) above what was measured; the range from low to high includes it.
By their numbers in this assay, from the lowest: compounds 1 and 3 (each within the scatter of the next); then compound 2.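

With the group para to a large group on this ring, methoxy in place of trifluoromethyl gives a clear change, with a 2.6-fold lower number from compound 2 to compound 3 (0.42 log units; beyond the scatter) beyond the scatter. The earlier step had shown a change of aryl group only, whereas this one isolates the group on that aromatic carbon. Compound 3, the 4-methoxyphenyl, and compound 1, the 3-methylphenyl, cannot be told apart, with a 1.1-fold higher number from compound 1 to compound 3 (0.06 log units; within the scatter) within the scatter. From the compounds shown here alone, whether chlorine, a hydroxyl or an amine on this aromatic carbon would side with methoxy or with trifluoromethyl stays open. No measurement at hand offers a reason for the difference.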